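Removing an Isobutyl Group from a Peptide-Like Inhibitor

A few compounds are considered here, and "the series" means these few. Any claim that something is new, unique, unknown or untested is made for them only; others in the source may bear on it.

Measured compounds:
compound 1, `CSCC[C@H](NC(=O)[C@H](CC(C)C)NC(=O)[C@H](CC(C)C)NC(=O)CC[C@H](NS(=O)(=O)c1ccc(Cl)c(C(F)(F)F)c1)C(=O)O)C(N)=O`, gives 780 nM
compound 2, `CSCC[C@H](NC(=O)[C@H](CC(C)C)NC(=O)[C@H](C)NC(=O)C[C@H](NS(=O)(=O)c1ccc(Cl)c(C(F)(F)F)c1)C(=O)O)C(N)=O`, gives 4700 nM

Both compounds were tested in an assay on isolated protein for inhibition of Matrilysin (Homo sapiens), read by fluorescence, with a stated time of 15 min; on this read-out lower numbers stand for stronger inhibition and higher numbers for weaker inhibition. Of the two numbers, compound 1 holds the lower one with 780 nM, and compound 2 with 4700 nM lies well beyond the usual scatter above it, so compound 1 is the stronger inhibitor of this pair. Compound 2 differs from compound 1 in more than one place at once, so the gap between their values cannot be tied to any single change; it only shows that the two structures are not equivalent.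

Compound 3, `CSCC[C@H](NC(=O)[C@H](CC(C)C)NC(=O)CNC(=O)CC[C@H](NS(=O)(=O)c1ccc(Cl)c(C(F)(F)F)c1)C(=O)O)C(N)=O`, has not yet been measured. It differs from compound 1 by one change: hydrogen in place of isobutyl on a saturated chain carbon bound to an amide-type nitrogen and a carbonyl carbon. In plain terms, one of the branched side groups of compound 1 is taken away entirely, leaving a bare hydrogen in its place.

The step from compound 1 to compound 3 is expected to weaken inhibition, with an estimated size of a 6.4-fold higher number from compound 1 to compound 3 (0.81 log units; beyond the scatter). For compound 3 the expected value is 5000 nM, with a likely range from 1500 nM to 20000 nM.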

Compound 3, half-maximal inhibitory concentration: 120 nM
For compound 3 the middle estimate is 42-fold (1.62 log units) above the measured one, and the stated range ends above it.
By their numbers in this assay, from the lowest: compound 3; then compound 1; then compound 2.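

In this assay, putting hydrogen in place of isobutyl on this saturated chain carbon, bound to an amide-type nitrogen and a carbonyl carbon, gives a 6.5-fold lower number from compound 1 to compound 3 (0.81 log units; beyond the scatter). Within the data shown here, this is the first single-change comparison, and it shows that the isobutyl group is not needed here for inhibition of this enzyme: the compound with the bare hydrogen is the stronger inhibitor of the pair, which compound 2, differing from compound 1 in more than one place, could not reveal. Nothing measured here explains why losing these four carbons goes with stronger inhibition.

From the compounds shown here alone, this single step marks only the two ends of a range at this position, so it remains open whether an ethyl group, a longer straight chain or a chain ending in an amine or a carboxylic acid would give a number closer to that of compound 3 or to that of compound 1. Going by these compounds, it also remains open whether the same exchange at the other isobutyl group, which compound 1 and compound 3 share, would change inhibition in the same direction.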